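E to Z at the double bond in the series

The source may report more compounds than this note shows. Statements on the series, on what has been measured and on what is new or still open speak of the compounds shown alone.

Measured in a functional assay on A549 cells (Homo sapiens) for inhibition; a higher number here means a weaker inhibitor, a lower number a stronger inhibitor
compound 1 `COc1cc(/C=C\c2cn(C(C)=O)c3ccccc23)cc(OC)c1OC` gives 2850 nM
compound 2 `COc1cc(/C=C/c2c[nH]c3ccccc23)cc(OC)c1OC` gives 3230 nM

Compound 2, with its double bond drawn E, stands within the usual scatter of compound 1, so these two numbers do not separate the pair. Among the measured compounds shown here, no step between measured compounds that differ in one place is available, and the effect of changing the double bond has not been observed directly.

Compound 3 `COc1cc(/C=C\c2c[nH]c3ccccc23)cc(OC)c1OC` is the next to be read against compound 2 (the two compounds have the same atoms and bonds and differ only in configuration as drawn: 1 of 1 stereo elements differ; a double bond is drawn E in compound 2 and Z in compound 3). Only the drawn configuration of the double bond changes. For the measured compounds named here, compound 1 (2850 nM) is the only measured compound with this bond drawn Z, and its value offers no clear sign of a large shift from compound 2 (3230 nM). However, it also carries an acetyl group that compound 3 lacks, so it is only a loose guide.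

A modest step towards a lower number in this assay is expected, though it may stay within the scatter. The estimated change is small to moderate (a 1.5-fold lower number from compound 2 to compound 3 (0.17 log units; within the scatter)). For compound 3 the expected value is 2200 nM (estimated range 350 nM to 6500 nM).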

Compound 3, half-maximal inhibitory concentration: 3230 nM
Beside the measured number, compound 3's estimate is 1.5-fold (0.17 log units) below it; low and high end bracket the measured number.
By their numbers in this assay, from the lowest: compounds 1, 2 and 3 (each within the scatter of the next).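

In this assay the double bond now has a direct reading, with no change at the digits printed from compound 2 to compound 3 (within the scatter), so the E and Z forms as drawn are not separated in this assay. This reading can be assigned to the double bond alone because of one structural point: the fact that compounds 2 and 3 differ only in the configuration as drawn. The aromatic nitrogen also gets its first one-place reading, hydrogen in place of acetyl on the Z form giving a 1.1-fold higher number from compound 1 to compound 3 (0.05 log units; within the scatter), so these two groups are not separated there either.

From the compounds shown here alone, it remains open whether the double bond stays without a readable effect when the aromatic nitrogen carries acetyl, or whether the acetyl reading carries over to the E form. Going by these compounds, it is also open whether a group of another kind on that nitrogen, such as a longer chain ending in an amine or a carboxylic acid, would move the number beyond the scatter in this assay.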